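A Fluorine Added to the Pyridyl Ring of Compound 3

The source may report more compounds than this note shows. Statements on the series, on what has been measured and on what is new or still open speak of the compounds shown alone.

Three compounds have been measured in an assay on isolated protein for inhibition of Nicotinamide phosphoribosyltransferase (Homo sapiens), read by fluorescence, with stated times of 5 min and 15 min; on this read-out higher numbers stand for weaker inhibition and lower numbers for stronger inhibition:
Compound 1, `Nc1ccccc1NC(=O)c1ccc(NC(=S)NCc2cccc(F)c2)cc1`, gives > 2000 nM, a limit of the assay.
Compound 2, `Nc1ccccc1NC(=O)c1ccc(NC(=S)NCc2ccccc2F)cc1`, gives > 2000 nM, also a limit of the assay.
Compound 3, `Nc1ccccc1NC(=O)c1ccc(NC(=S)NCc2cccnc2)cc1`, gives 116 nM.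

Compound 3 thus holds the only number shown; the other two values sit at the limit of > 2000 nM in this assay, at which 2 of the 3 values shown sit. The steps of an at least 17-fold lower number from compound 1 to compound 3 (1.23 log units; beyond the scatter) and an at least 17-fold lower number from compound 2 to compound 3 (1.23 log units; beyond the scatter) are both large, and each exchanges a fluorophenyl for pyridin-3-yl. Compound 4, `Nc1ccccc1NC(=O)c1ccc(NC(=S)NCc2cncc(F)c2)cc1`, differs from compound 3 by fluoro in place of hydrogen on an aromatic carbon. Among the measured compounds shown here, no measured step exchanges hydrogen for fluoro on a ring that is kept, so the two large steps do not bear on this change directly. The step of a 1.3-fold higher number from compound 3 to compound 4 (0.11 log units; within the scatter) is expected to stay within the scatter. Compound 4 is estimated at 150 nM, between 50 nM and 500 nM, in this assay.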

Compound 4, half-maximal inhibitory concentration: > 2000 nM
Compound 4 ended at the assay's limit; the forecaster's own chance of this, stated with the estimate: 10%; at least 13-fold (1.12 log units) between middle value and limit.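

Among the compounds shown here, the step of an at least 17-fold higher number from compound 3 to compound 4 (1.23 log units; beyond the scatter) is the first exchange of hydrogen for fluoro on a kept ring, and it shows that keeping the ring nitrogen does not by itself preserve the value of compound 3. The steps to compound 4 from compound 1 and compound 2 cannot be read. Compound 4 thus adds to the values held at a limit of the assay: the limit of > 2000 nM in this assay, at which 3 of the 4 values shown sit.

On these data alone, whether this drop belongs to fluoro alone or also to a chloro, methyl or methoxy group at the same carbon stays open. Also open, as far as these compounds go, is how fluoro would act on another carbon of the pyridin-3-yl ring.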